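This account rests on a few compounds, and the source may have more. Where it says the series, first, only, none or still open, it means among the compounds named here.

Measured so far in a functional assay on NCI-H460 cells (Homo sapiens) for inhibition, read by sulforhodamine B assay, with a stated time of 48 h; a lower number here means a stronger inhibitor of growth, a higher number a weaker inhibitor of growth:
compound 1, `COc1ccc(C(=O)/C=C/c2cc(-c3cc(OC)c(OC)c(OC)c3)n[nH]2)cc1OC`, giving 3330 nM
compound 2, `COc1cc(-c2cc(/C=C/C(=O)c3ccc(F)c(F)c3)[nH]n2)cc(OC)c1OC`, giving 8240 nM

Going by the values given here, compound 1 stands lowest of the two numbers; the nearest is compound 2, and the only single-point step in the set is a 2.5-fold higher number from compound 1 to compound 2 (0.39 log units; beyond the scatter), a change on the ring attached to the carbonyl carbon.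

Compound 3, `COc1cc(C(=O)/C=C/c2cc(-c3cc(OC)c(OC)c(OC)c3)n[nH]2)cc(OC)c1OC`, is not yet measured. It differs from compound 1 by methoxy in place of hydrogen on an aromatic carbon. This change sits on the same ring that separates compound 1 from compound 2, but the change itself, a methoxy group entering where hydrogen stood, has no measured counterpart among these compounds. The step from compound 1 to compound 2 shows that altering this ring moves the number by a modest amount, so a modest movement is plausible here as well, yet its direction cannot be read from the two values at hand. A step within or near the scatter is expected, as a 1.2-fold lower number from compound 1 to compound 3 (0.09 log units; within the scatter). Compound 3 is therefore estimated at 2700 nM in this assay, with a range from 1000 nM to 7500 nM.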

Compound 3, concentration for total growth inhibition: 4330 nM
Beside the measured number, compound 3's estimate is 1.6-fold (0.21 log units) below it; the measured number falls inside the stated range.
By their numbers in this assay, from the lowest: compounds 1, 3 and 2 (each within the scatter of the next, the first and the last beyond it).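

In this assay, going by these compounds alone, adding a methoxy group at this place gives a 1.3-fold higher number from compound 1 to compound 3 (0.11 log units; within the scatter), the first reading of a group entering on an aromatic carbon of the ring attached to the carbonyl carbon, ortho to a methoxy group and meta to a large group. The step lies within the scatter, so compound 1 and compound 3 cannot be told apart and this position takes the added methoxy without a measurable shift. Within the data shown here, on the same ring, the exchange of 3,4-dimethoxyphenyl for 3,4-difluorophenyl remains the only step beyond the scatter, at a 2.5-fold higher number from compound 1 to compound 2 (0.39 log units; beyond the scatter), and no measurement available here explains the difference between these two changes.

From the compounds shown here alone, whether an amine, a carboxylic acid or a longer chain such as ethoxy at this aromatic carbon would give a step beyond the scatter stays open. The parts of the core of compound 1 away from this ring also remain without any step, so their contribution to growth inhibition cannot be judged from these compounds.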